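Mirror-image step from compound 2 to compound 3

This account rests on a few compounds, and the source may have more. Where it says the series, first, only, none or still open, it means among the compounds named here.

Compound 1 `O=C(O)[C@@H](CO)NC(=O)[C@H]1C[C@@H](O)CN1`: 24000 nM
Compound 2 `O=C(N[C@H](CO)C(=O)O)[C@@H]1C[C@H](O)CN1`: 22200 nM

Both values come from an ADME assay on the whole organism (Mus musculus, strain C57BL/6) for pharmacokinetics, read by HPLC, with a stated time of 6 h, at a dose of 25 mg/kg by the oral route; a lower number here means less compound in the circulation, a higher number more compound in the circulation at the dose given. Compound 2, at 22200 nM, stands within the scatter of compound 1. The next structure is compound 3 `O=C(O)[C@H](CO)NC(=O)[C@H]1C[C@@H](O)CN1`, and its change from compound 2 is the two compounds have the same atoms and bonds and differ only in configuration as drawn: 3 of 3 stereo elements differ (all stereocentres are inverted: mirror images); a stereocentre at a saturated chain carbon is drawn R in compound 2 and S in compound 3; a stereocentre at a saturated ring carbon is drawn S in compound 2 and R in compound 3; a stereocentre at a saturated ring carbon is drawn S in compound 2 and R in compound 3. Among the compounds with values here, one measured step bears on this: a 1.1-fold lower number from compound 1 to compound 2 (0.03 log units; within the scatter). Its relevance lies in the fact that compounds 1 and 2 differ only in the configuration as drawn. Within the data shown here, that step inverts the two saturated ring carbons only, whereas the change to compound 3 also inverts the saturated chain carbon, so that centre has no measured step of its own. Among the measured compounds shown here, with only that small step as a guide, no step beyond the scatter is expected in this assay. The expected step is a 1.0-fold higher number from compound 2 to compound 3 (0.02 log units; within the scatter). Compound 3 is estimated at 23000 nM, with an expected range of 11000 nM to 46000 nM.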

Compound 3, maximal plasma concentration: 22700 nM
Estimate against measurement, compound 3: 1.0-fold (0.01 log units) above; low and high end bracket the measured number.
By their numbers in this assay, from the lowest: compounds 2, 3 and 1 (each within the scatter of the next).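

In this assay, the saturated chain carbon now has a step of its own, a 1.1-fold lower number from compound 1 to compound 3 (0.02 log units; within the scatter), and inverting that centre alone stays within the scatter. Inverting all three stereocentres together gives a 1.0-fold higher number from compound 2 to compound 3 (0.01 log units; within the scatter), so this read-out does not separate the mirror-image pair either. Neither comparison carries any other structural change, as the mirror-image pair shows: the fact that compounds 2 and 3 differ only in the configuration as drawn

All three compounds share the same groups, so they say nothing about how a methyl ester in place of the carboxylic acid, or a methyl ether in place of a hydroxyl, would affect the maximal plasma concentration. From the compounds shown here alone, whether configuration stays this silent on any other scaffold or at any other dose also remains open.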